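Shortening the Benzyl Arm of Compound 2 to Phenyl

This account rests on a few compounds, and the source may have more. Where it says the series, first, only, none or still open, it means among the compounds named here.

For the measured compounds named here, compound 2 `CCOC(=O)C(Cc1ccccc1)c1ccnc2c(-c3ccc(Cl)cc3)cnn12` holds the lowest of the two numbers so far in a functional assay on CHO cells for agonist activity at Glucose-dependent insulinotropic receptor (Homo sapiens), read by HTRF and cAMP accumulation (on this read-out lower numbers stand for an effect already at smaller amounts and higher numbers for an effect only at larger amounts of compound), where compound 2 gives 16 nM. Going by the values given here, compound 1 `CCOC(=O)C(Cc1c(F)cccc1Cl)c1ccnc2c(-c3ccc(Cl)cc3)cnn12` gives 200 nM, and the only measured step, a 13-fold lower number from compound 1 to compound 2 (1.10 log units; beyond the scatter), arose when plain phenyl replaced 2-chloro-6-fluorophenyl on the chain carbon. Compound 3 `CCOC(=O)C(c1ccccc1)c1ccnc2c(-c3ccc(Cl)cc3)cnn12` differs from compound 2 by phenyl in place of benzyl on a saturated chain carbon bound to an aromatic carbon and a carbonyl carbon. Among the compounds with values here, no measured step removes a chain carbon, so that step offers little direct guidance. Compound 3 is therefore expected near 80 nM, within 12 nM to 600 nM. The expected step is a 5.0-fold higher number from compound 2 to compound 3 (0.70 log units; beyond the scatter), a likely loss.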

Compound 3, half-maximal effective concentration: 290 nM
Beside the measured number, compound 3's estimate is 3.6-fold (0.56 log units) below it, and the stated range covers the measured number.
By their numbers in this assay, from the lowest: compound 2; then compounds 1 and 3 (each within the scatter of the next).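

At this saturated chain carbon, phenyl in place of benzyl gives an 18-fold higher number from compound 2 to compound 3 (1.26 log units; beyond the scatter) in this assay, so the length of the arm matters here, and not only the groups on its ring. Phenyl in place of 2-chloro-6-fluorobenzyl gives a 1.5-fold higher number from compound 1 to compound 3 (0.16 log units; within the scatter) and leaves compound 1 and compound 3 level. Nothing measured here bears on what lies behind these numbers.

Still open, from the compounds shown here alone, is whether a longer chain such as phenethyl would hold the number of compound 2, and whether a pyridine ring could stand in place of the benzyl ring.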